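A few compounds are considered here, and "the series" means these few. Any claim that something is new, unique, unknown or untested is made for them only; others in the source may bear on it.

Measured in an ADME assay (liver) for metabolic stability, with Liver microsome (Rattus norvegicus) as the target, using microsomes and NADPH, with a stated time of 30 min, at 37 degrees C, tested at 1 uM (on this read-out lower numbers stand for slow clearance and higher numbers for fast clearance), and each a limit of the assay:
Compound 1 `CC(O)(c1ccc(-c2ncc(S(=O)(=O)c3ccc(N)nc3)s2)c(Cl)c1)C(F)(F)F` gives < 14 mL.min-1.g-1 as a limit
Compound 2 `C[C@](O)(c1ccc(-c2ncc(S(=O)(=O)c3ccc(N)nc3)s2)c(Cl)c1)C(F)(F)F` gives < 14 mL.min-1.g-1 as a limit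
Compound 3 `CC(O)(CO)c1ccc(-c2ncc(S(=O)(=O)c3ccc(N)nc3)s2)c(Cl)c1` gives < 14 mL.min-1.g-1 as a limit

Compound 3 stands at < 14 mL.min-1.g-1 as a limit and not a number. The same holds across the set, with the limit of < 14 mL.min-1.g-1 in this assay, at which 3 of the 3 values shown sit, as the whole of the picture.

Compound 4 `C[C@@](O)(CO)c1ccc(-c2ncc(S(=O)(=O)c3ccc(N)nc3)s2)c(Cl)c1` is compound 3 with one change in how it is drawn: the two compounds have the same atoms and bonds; at least one stereo element is drawn with a configuration in one of them and without one in the other: 1 of 1 stereo elements differ; a stereocentre at a saturated chain carbon is drawn without a configuration in compound 3 and S in compound 4 and nothing else. Within the data shown here, the closest precedent is a step that the two limits leave unreadable from compound 1 to compound 2 and it is the same kind of change, set by the fact that one of compounds 1 and 2 is drawn with a defined configuration and the other without, at the place where they differ in that pair. Neither a step that the two limits leave unreadable from compound 1 to compound 3 nor the companion a step that the two limits leave unreadable from compound 2 to compound 3 gives a size to carry over. No step beyond the usual scatter is therefore expected in this assay and the estimate is a step that the limit leaves unreadable from compound 3 to compound 4 with no direction favoured. Compound 4 is expected at 10 mL.min-1.g-1 with an estimated range from 6 mL.min-1.g-1 to 16 mL.min-1.g-1 and will most likely be reported as a limit again.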

Compound 4, intrinsic clearance in microsomes: < 14 mL.min-1.g-1
Compound 4 was reported as a limit; the forecaster's own chance of this, stated with the estimate: 85%; the middle value does not contradict the limit.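

In this assay compound 4 gives < 14 mL.min-1.g-1, a limit of the assay. No step can be read between compound 4 and compound 1, compound 2 or compound 3, which are also limits. The compounds shown leave open whether stereochemistry or hydroxymethyl in place of trifluoromethyl alters clearance at all.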